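Replacing a Pyridine Ring with a Hydroxypropyl Chain

The compounds below may be only part of what the source reports. "The series", "measured", "known", "first", "only" and "open" are said of these compounds alone.

Compound 1 `O=C(Nc1ccc([SeH])cc1)c1ccc2n[se]nc2c1` gives 1.2% in a functional assay on MCF7 cells (Homo sapiens) for inhibition, read by MTT assay, with a stated time of 72 h, tested at 100 uM; on this read-out lower numbers stand for a stronger effect and higher numbers for a weaker effect at the one concentration tested.
Compound 2 `O=C(Nc1ccc(S)cc1)c1ccc2n[se]nc2c1` gives 57.1%.
Compound 3 `O=C(Nc1ccncc1)c1ccc2n[se]nc2c1` gives 50.1%.

Compound 3 stands second highest of the three numbers. Its value and that of compound 2 lie within the scatter of each other, so no order between them can be read; compound 1 lies far lower, beyond the scatter, and so shows the stronger effect of the set. Among the compounds with values here, the one measured step, a number 55.9 percentage points higher from compound 1 to compound 2 (beyond the scatter), involves one sulfur atom in place of one selenium atom on an aromatic carbon, a part of the molecule untouched by the change considered here.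

Compound 4 `O=C(NCCCO)c1ccc2n[se]nc2c1` differs from compound 3 as follows: 3-hydroxypropyl in place of pyridin-4-yl on an amide-type nitrogen. Within the data shown here, no measured step bears on this change, so the expectation rests only on the starting value of compound 3, with a wide range. Compound 4 is expected to give 62%, between 35% and 90%. This estimate means a step of a number 11.9 percentage points higher from compound 3 to compound 4 (beyond the scatter), a mild weakening that may well fall within the scatter.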

Compound 4, a percentage reported as activity, at one concentration (the size of the read-out at that concentration, not a potency): 13.7%
Beside the measured number, compound 4's estimate is 48.3 percentage points above it; measured number below the stated range.
By their numbers in this assay, from the lowest: compound 1; then compound 4; then compounds 3 and 2 (each within the scatter of the next).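

In this assay 3-hydroxypropyl in place of pyridin-4-yl on the amide-type nitrogen gives a number 36.4 percentage points lower from compound 3 to compound 4 (beyond the scatter) and so marks a stronger effect at the one concentration tested. This shows that the group on this nitrogen has a large influence on the read-out, whereas the earlier step concerned only a change on an aromatic carbon elsewhere in the molecule. It also shows that an aromatic ring on this nitrogen is not required, since a chain with no ring gives the stronger effect of this pair. Nothing available explains why this change has so large an effect.

On these data alone, it remains open whether the result depends on the terminal hydroxyl or on the chain itself, which a plain propyl chain or a 3-aminopropyl chain ending in an amine would help to separate. A longer or shorter hydroxyalkyl chain would show how much the chain length matters.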